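Adding a Propyl Chain at a Fused Ring Carbon

The source may hold more compounds than are shown below. What is called first, only, known or untested is meant among the compounds shown, and "the series" means these compounds.

Compound 3 `CCCCOC(=O)NS(=O)(=O)c1ccc(CCC)cc1-c1ccc(Cn2cnc3ccccc32)cc1` gives 29 nM in an assay on membranes from HEK293 cells for displacement of a labelled ligand from Type-2 angiotensin II receptor (Homo sapiens), read by radioligand binding (a lower number here means a stronger inhibitor, a higher number a weaker inhibitor), the highest of the three measured numbers. Compound 2 `CCCCOC(=O)NS(=O)(=O)c1ccc(CCC)cc1-c1ccc(Cn2c(CC(C)C)nc3ccccc32)cc1` gives 19 nM in this assay, within the scatter of compound 3, while compound 1 `CCCc1ccc(S(=O)(=O)NC(=O)OCCCC(F)(F)F)c(-c2ccc(Cn3c(C(C)(C)C)nc4ccccc43)cc2)c1` gives 4.5 nM in this assay, a number beyond the scatter below compound 3. Compound 4 `CCCCOC(=O)NS(=O)(=O)c1ccc(CCC)cc1-c1ccc(Cn2c(CCC)nc3ccccc32)cc1` differs from compound 3 by propyl in place of hydrogen on an aromatic carbon, in words: propyl in place of hydrogen on an aromatic carbon. Among the compounds with values here, the one step that bears on this is a 1.5-fold higher number from compound 2 to compound 3 (0.18 log units; within the scatter), the loss of a chain at that same carbon. Putting a shorter chain back is therefore expected to move the number little, if at all, beyond the scatter, so compound 4 is estimated at 20 nM, within 8 nM to 50 nM in this assay, a step of a 1.5-fold lower number from compound 3 to compound 4 (0.16 log units; within the scatter).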

Compound 4, inhibition constant: 14 nM
Compound 4: the middle estimate sits 1.4-fold (0.15 log units) above what was measured; low and high end bracket the measured number.
By their numbers in this assay, from the lowest: compound 1; then compounds 4, 2 and 3 (each within the scatter of the next, the first and the last beyond it).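

In this assay, propyl in place of hydrogen on this aromatic carbon between two ring nitrogen atoms gives a 2.1-fold lower number from compound 3 to compound 4 (0.32 log units; beyond the scatter), a modest step that lies just beyond the scatter, whereas the earlier step at this carbon did not. Changing the chain from isobutyl to propyl gives a 1.4-fold lower number from compound 2 to compound 4 (0.13 log units; within the scatter), so these two chains cannot be told apart here. Nothing measured here offers a reason for either step. Still open, on these data alone, is how a longer chain such as pentyl would read at this carbon. As far as these compounds go, an amine or a carboxylic acid there is equally open.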